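The compounds below may be only part of what the source reports. "The series", "measured", "known", "first", "only" and "open" are said of these compounds alone.

Measured so far:
- Compound 1, `Cc1nc(C)c([C@H](OC(C)(C)C)C(=O)O)c(N2CCC(C)(C)CC2)c1-c1ccc(OCCc2ccc(F)cc2F)cc1`: 1.08 h
- Compound 2, `Cc1nc(C)c([C@H](OC(C)(C)C)C(=O)O)c(N2CCC(C)(C)CC2)c1-c1ccc(OCCc2ccccn2)cc1`: 0.5 h
- Compound 3, `Cc1nc(C)c([C@H](OC(C)(C)C)C(=O)O)c(N2CCC(C)(C)CC2)c1-c1ccc(OCCc2cccnc2)cc1`: 0.367 h

All three share one core and differ only in the aromatic group that sits on a saturated chain carbon, two bonds along the chain from an oxygen on an aromatic ring. In an ADME assay on microsomes from liver (Homo sapiens) for metabolic stability, read by LC-MS, tested at 0.5 uM (on this read-out lower numbers stand for a shorter-lived compound and higher numbers for a longer-lived compound), compound 1 gives 1.08 h and stands beyond the scatter above the other two, as the steps of a 2.2-fold lower number from compound 1 to compound 2 (0.33 log units; beyond the scatter) and a 2.9-fold lower number from compound 1 to compound 3 (0.47 log units; beyond the scatter) show. Compound 2 and compound 3, on the other hand, lie within the scatter of each other: a 1.4-fold lower number from compound 2 to compound 3 (0.13 log units; within the scatter).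

Compound 4, `Cc1nc(CCOc2ccc(-c3c(C)nc(C)c([C@H](OC(C)(C)C)C(=O)O)c3N3CCC(C)(C)CC3)cc2)cs1`, has not yet been measured in this assay. It differs from compound 3 in one place: 2-methyl-1,3-thiazol-4-yl in place of pyridin-3-yl on a saturated chain carbon, two bonds along the chain from an oxygen on an aromatic ring. Going by the values given here, no measured step involves this thiazole group, so the only guide is that swapping one heteroaromatic ring for another, as from compound 2 to compound 3, gave a step within the scatter. On that basis the step from compound 3 to compound 4 is expected to be small, a 1.1-fold higher number from compound 3 to compound 4 (0.04 log units; within the scatter), and the estimate for compound 4 in this assay is 0.4 h, with a range from 0.2 h to 0.9 h.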

Compound 4, half-life: 0.683 h
Compound 4: the middle estimate sits 1.7-fold (0.23 log units) below what was measured; low and high end bracket the measured number.
By their numbers in this assay, from the lowest: compounds 3, 2, 4 and 1 (each within the scatter of the next, the first and the last beyond it).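

In this assay compound 4 stays within the scatter of all three other compounds (a 1.9-fold higher number from compound 3 to compound 4 (0.27 log units; within the scatter); a 1.4-fold higher number from compound 2 to compound 4 (0.14 log units; within the scatter); a 1.6-fold lower number from compound 1 to compound 4 (0.20 log units; within the scatter)). Compound 1 stands beyond the scatter above compound 2 and compound 3, yet compound 4, with its five-membered 2-methyl-1,3-thiazol-4-yl ring, cannot be separated from either side, so at this position the half-life numbers no longer fall into two clear groups. Nothing available here explains this result.

The compounds shown leave open what the methyl group on the thiazole contributes, which a 1,3-thiazol-4-yl without that methyl would help to settle. They also leave open what the two fluorines of compound 1 contribute, a question for a plain phenyl group at the same position.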